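Ethyl for a Substituted Phenyl on the Core Nitrogen

This account rests on a few compounds, and the source may have more. Where it says the series, first, only, none or still open, it means among the compounds named here.

Compound 2 `CNC(=O)c1ccc(-n2c(=O)n(-c3ccc(C#N)c(C(F)(F)F)c3)c3ccccc32)cc1F` gives 8810 nM in a physicochemical assay for solubility (a higher number here means a more soluble compound, a lower number a less soluble compound), the higher of the two single numbers, with compound 1 `N#Cc1ccc(-n2c(=O)[nH]c3ccccc32)cc1C(F)(F)F` nearest at 7900 nM; the step of a 1.1-fold higher number from compound 1 to compound 2 (0.05 log units; within the scatter) shows that the 3-fluoro-4-(methylcarbamoyl)phenyl hardly moved the number. Compound 3 `CC(c1ccccc1)n1c(=O)n(-c2ccc(C#N)c(C(F)(F)F)c2)c2ccccc21` bears another group on the same nitrogen and gives 5580 nM; 4410 nM (2 entries). Compound 4 `CCn1c(=O)n(-c2ccc(C#N)c(C(F)(F)F)c2)c2ccccc21` differs from compound 2 by ethyl in place of 3-fluoro-4-(methylcarbamoyl)phenyl on an aromatic nitrogen. For the measured compounds named here, the one measured step at this position lay within the scatter, and the several entries of compound 3 the several entries of compound 3 in this assay, 5580 nM; 4410 nM (2 entries) sit close to compound 2. Compound 4 is therefore expected to show no step beyond the scatter, a 1.3-fold lower number from compound 2 to compound 4 (0.10 log units; within the scatter). The value of compound 4 is estimated at 7000 nM, with a range from 3500 nM to 14000 nM.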

Compound 4, solubility: 3470 nM
Estimate against measurement, compound 4: 2.0-fold (0.30 log units) above; measured number below the stated range.
By their numbers in this assay, from the lowest: compound 4; then compounds 1 and 2 (each within the scatter of the next).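

In this assay, for the compounds shown here, this nitrogen proves less indifferent than the earlier compounds suggested: ethyl brings a step beyond the scatter, a 2.5-fold lower number from compound 2 to compound 4 (0.40 log units; beyond the scatter). Ethyl also falls short of hydrogen, with a 2.3-fold lower number from compound 1 to compound 4 (0.36 log units; beyond the scatter), although hydrogen and the 3-fluoro-4-(methylcarbamoyl)phenyl lie within the scatter of each other. Nothing measured here gives a reason for this fall. Going by these compounds, whether a longer chain, an amine or a carboxylic acid on this nitrogen would stay with ethyl or return to the level of compound 2 remains open.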